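From 2,5-difluorophenyl to 4-nitrophenyl on a shared core

A few compounds are considered here, and "the series" means these few. Any claim that something is new, unique, unknown or untested is made for them only; others in the source may bear on it.

Measured so far in a functional assay on MCF7 cells (Homo sapiens) for antiproliferative activity, read by MTT assay, with a stated time of 72 h; a higher number here means a weaker inhibitor, a lower number a stronger inhibitor:
compound 1 `COc1cc(-n2cnc3ccc(-c4ccc(C)cc4F)cc32)cc(OC)c1OC` (56 nM)
compound 2 `COc1ccc(-c2ccc3ncn(-c4cc(OC)c(OC)c(OC)c4)c3c2)cc1F` (520 nM)
compound 3 `COc1cc(-n2cnc3ccc(-c4cc(F)ccc4F)cc32)cc(OC)c1OC` (6420 nM)

Compound 3 stands highest of the three and is thus the weakest inhibitor here. Compound 4 `COc1cc(-n2cnc3ccc(-c4ccc([N+](=O)[O-])cc4)cc32)cc(OC)c1OC` has 4-nitrophenyl in place of 2,5-difluorophenyl on an aromatic carbon. Two measured steps changed this same place: a 110-fold higher number from compound 1 to compound 3 (2.06 log units; beyond the scatter) and a 12-fold higher number from compound 2 to compound 3 (1.09 log units; beyond the scatter) were both large, and each ended at 2,5-difluorophenyl. Going by the values given here, no measured compound carries a nitro group, so these steps are only a loose guide. A move of moderate size towards a lower number is therefore expected in this assay. The expected change is a 7.1-fold lower number from compound 3 to compound 4 (0.85 log units; beyond the scatter) in size and remains uncertain. The estimated value for compound 4 is 900 nM with an expected range (150 nM to 5000 nM).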

Compound 4, half-maximal inhibitory concentration: 740 nM
The estimate for compound 4 lay 1.2-fold (0.09 log units) above the measured number; low and high end bracket the measured number.
By their numbers in this assay, from the lowest: compound 1; then compounds 2 and 4 (each within the scatter of the next); then compound 3.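

In this assay, 4-nitrophenyl gives an 8.7-fold lower number from compound 3 to compound 4 (0.94 log units; beyond the scatter) and so shows that this position can carry a ring without fluorine and still sit well clear of the 2,5-difluorophenyl compound. Exchanging 3-fluoro-4-methoxyphenyl for it gives a 1.4-fold higher number from compound 2 to compound 4 (0.15 log units; within the scatter), so these two quite different groups cannot be told apart here. The 2-fluoro-4-methylphenyl group keeps its lead, with a 13-fold higher number from compound 1 to compound 4 (1.12 log units; beyond the scatter) as the cost of leaving it.

The compounds shown leave open whether an amine or a carboxylic acid in place of the nitro group would hold this level. No measurement given here accounts for these differences.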